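The compounds below may be only part of what the source reports. "The series", "measured", "known", "first", "only" and "open" are said of these compounds alone.

Of the compounds shown here, two from this set have been tested in an ADME assay on Vero cells (Chlorocebus sabaeus) for cytotoxicity, read by MTT assay, with a stated time of 72 h; on this read-out higher numbers stand for lower toxicity in this test and lower numbers for higher toxicity in this test. Compound 1, with the structure `O=C1Oc2ccccc2N/C1=C\C(=O)c1cccs1`, gives only a limit of the assay in this assay, namely > 1840000 nM. Among the compounds with values here, compound 2, with the structure `O=C1Oc2ccccc2N/C1=C\C(=O)c1cccc(Cl)c1`, gives a number in this assay, 1610000 nM; it is the only compound with a plain number. The step of an at least 1.1-fold lower number from compound 1 to compound 2 (0.05 log units; that floor lies within the scatter) rests on a limit on one side, as the line the limit of > 1840000 nM in this assay, at which 1 of the 2 values shown sits, records. Compound 3, with the structure `COC(=O)/C=C1\Nc2ccccc2OC1=O`, has not been tested in this assay. It differs from compound 2 in one place: methoxy in place of 3-chlorophenyl on a carbonyl carbon. Within the data shown here, no measured step covers an exchange of this kind, and the one step that exists lies within the scatter, so no shift beyond the scatter is expected for a 1.1-fold lower number from compound 2 to compound 3 (0.03 log units; within the scatter). Compound 3 is therefore expected to give about 1500000 nM in this assay, within a range from 500000 nM to 2000000 nM.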

Compound 3, half-maximal cytotoxic concentration: > 2280000 nM
Compound 3 ended at the assay's limit (the forecaster's own chance of this, stated with the estimate: 40%); middle value at least 1.5-fold (0.18 log units) away from the limit.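

Until now this place on a carbonyl carbon held only ring groups; methoxy, which has no ring, brings no lower number in this assay, with an at least 1.4-fold higher number from compound 2 to compound 3 (0.15 log units; that floor lies within the scatter). The value of compound 3 is a limit and not a plain number: the limit of > 2280000 nM in this assay, at which 1 of the 3 values shown sits. Compound 1 and compound 3 both stop at limits, so the step between them cannot be read.

The compounds shown leave open whether an amine, a carboxylic acid or a chain longer than methoxy on this carbonyl carbon would give a number as high as these or a clearly lower one. They also leave open whether any exchange at this place can move the number beyond the usual scatter, for no step shown so far is read as doing so.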